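This account rests on a few compounds, and the source may have more. Where it says the series, first, only, none or still open, it means among the compounds named here.

Compound 1, `CC(C)=CCc1cc(C(=O)Nc2cc3ccc(OCCCN(C)C(C)C)c(C)c3oc2=O)ccc1O`: 1050 nM
Compound 2, `CC(C)=CCc1cc(C(=O)Nc2cc3ccc(OCCCN(C)C(C)(C)C)c(C)c3oc2=O)ccc1O`: 1140 nM
Compound 3, `CC(C)=CCc1cc(C(=O)Nc2cc3ccc(OCCCNCc4ccccc4)c(C)c3oc2=O)ccc1O`: 910 nM

These three compounds were examined in a functional assay on MCF7 cells (Homo sapiens) for antiproliferative activity; on this read-out higher numbers stand for weaker inhibition and lower numbers for stronger inhibition. Compound 1 and compound 3 share one core and differ at the amine end of the chain, (benzylamino in place of isopropyl(methyl)amino on a saturated chain carbon, three bonds along the chain from an oxygen on an aromatic ring), a change that gave a 1.2-fold lower number from compound 1 to compound 3 (0.06 log units; within the scatter). From compound 1 to compound 2 the change is methyl in place of hydrogen on a saturated chain carbon bound to an amine nitrogen and two saturated chain carbons, and it gave a 1.1-fold higher number from compound 1 to compound 2 (0.04 log units; within the scatter); compound 2 and compound 3 are separated by a 1.3-fold lower number from compound 2 to compound 3 (0.10 log units; within the scatter). All three numbers lie within the usual scatter of one another.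

Compound 4, `CC(C)=CCc1cc(C(=O)Nc2cc3ccc(OCCCN[C@H](C)c4ccccc4)c(C)c3oc2=O)ccc1O`, has not yet been measured. It differs from compound 3 by methyl in place of hydrogen on a saturated chain carbon bound to an amine nitrogen and an aromatic carbon. This is the same kind of change as that from compound 1 to compound 2, but the place differs: there the carbon is bound to an amine nitrogen and two saturated chain carbons, here to an amine nitrogen and an aromatic carbon. Because the earlier change gave a 1.1-fold higher number from compound 1 to compound 2 (0.04 log units; within the scatter), the step from compound 3 to compound 4 is expected to be a 1.0-fold higher number from compound 3 to compound 4 (0.02 log units; within the scatter) in this assay. Compound 4 is therefore estimated at 950 nM, with a likely range from 450 nM to 2000 nM.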

Compound 4, half-maximal inhibitory concentration: 1450 nM
The estimate for compound 4 lay 1.5-fold (0.18 log units) below the measured number, and the stated range covers the measured number.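

In this assay, methyl in place of hydrogen on a saturated chain carbon bound to an amine nitrogen and an aromatic carbon gave a 1.6-fold higher number from compound 3 to compound 4 (0.20 log units; within the scatter), while the wider comparisons at the amine end gave a 1.3-fold higher number from compound 2 to compound 4 (0.10 log units; within the scatter) and a 1.4-fold higher number from compound 1 to compound 4 (0.14 log units; within the scatter). Set beside the earlier step, the methyl change reads alike on the two cores: the same change on two cores in this assay, a 1.1-fold higher number (0.04 log units; within the scatter) from compound 1 to compound 2 and a 1.6-fold higher number (0.20 log units; within the scatter) from compound 3 to compound 4, 1.5-fold (0.17 log units) apart, within the scatter of two such steps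

For the compounds shown here, this agreement shows only that neither pair departs from the scatter. It does not show that the methyl change has a real effect on either core, and two pairs of this size cannot establish a rule for carrying it to other cores in the series.

The compounds shown leave open whether the mirror-image form of the (1-phenylethyl)amino group, a longer chain leading to the amine, or a carboxylic acid in place of the amine would give a number beyond the scatter. They also leave open whether the methyl change would read the same on any other amine.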